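A side-chain exchange from compound 3 to compound 4

A few compounds are considered here, and "the series" means these few. Any claim that something is new, unique, unknown or untested is made for them only; others in the source may bear on it.

Of the compounds shown here, three built on a shared core have been measured in a functional assay on HeLa cells (Homo sapiens) for cytotoxicity, read by MTT assay; on this read-out higher numbers stand for weaker inhibition and lower numbers for stronger inhibition. There, compound 1 `CCCCC(CC(=O)O[C@H](CC=C(C)C)C1=CC(=O)c2c(O)ccc(O)c2C1=O)OC(C)=O` gives 73500 nM and compound 2 `CC(C)=CC[C@@H](OCC(C)O)C1=CC(=O)c2c(O)ccc(O)c2C1=O` gives 24700 nM. Compound 3 `CCC(CO[C@H](CC=C(C)C)C1=CC(=O)c2c(O)ccc(O)c2C1=O)OC(C)=O` gives 44000 nM, which lies within the scatter of both of the others, so it holds no separate rank among them.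

The next structure is compound 4 `CCCC(C)(O)CC(=O)O[C@H](CC=C(C)C)C1=CC(=O)c2c(O)ccc(O)c2C1=O`, and it is still unmeasured. It carries (2-hydroxy-2-methylpentyl)carbonyl in place of 2-acetoxybutyl on an oxygen on a saturated carbon.

Among the measured compounds shown here, no measured step covers this exact exchange. The nearest evidence is a single step on the same side chain, a 1.8-fold higher number from compound 2 to compound 3 (0.25 log units; within the scatter), which stays within the scatter even though it replaces 1-hydroxyethyl with 1-acetoxypropyl. That one step is thin support, but it gives no reason to expect a large shift in either direction. The estimate therefore means a 1.1-fold lower number from compound 3 to compound 4 (0.04 log units; within the scatter), an expected step that stays inside the scatter. In this assay, compound 4 is estimated at 40000 nM, with an expected range from 18000 nM to 85000 nM.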

Compound 4, half-maximal inhibitory concentration: 72000 nM
Beside the measured number, compound 4's estimate is 1.8-fold (0.26 log units) below it; the range from low to high includes it.
By their numbers in this assay, from the lowest: compounds 2, 3, 4 and 1 (each within the scatter of the next, the first and the last beyond it).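

In this assay, the exchange at this position, (2-hydroxy-2-methylpentyl)carbonyl in place of 2-acetoxybutyl on an oxygen on a saturated carbon, stays within the scatter (a 1.6-fold higher number from compound 3 to compound 4 (0.21 log units; within the scatter)), as does the change of 1-acetoxypentyl to 1-hydroxy-1-methylbutyl on a saturated chain carbon bound to a carbonyl carbon (a 1.0-fold lower number from compound 1 to compound 4 (0.01 log units; within the scatter)). Among the compounds shown here, what the earlier compounds did not show is a step at this position that clears the scatter: (2-hydroxy-2-methylpentyl)carbonyl in place of 2-hydroxypropyl gives a modest one (a 2.9-fold higher number from compound 2 to compound 4 (0.46 log units; beyond the scatter)), so the side chain on this oxygen can move the read-out measurably. Both groups in that step carry a hydroxy group, so a free hydroxy group on the side chain does not by itself go with the lower number, and compound 2 and compound 4 sit on opposite sides of this single separated pair.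

Nothing at hand explains any of these steps.

The compounds shown also leave open how a side chain ending in an amine or a carboxylic acid would read on this oxygen, and whether a longer chain would widen the one gap seen here.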